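Sidechain hydroxy removal on the core of compound 1

This account rests on a few compounds, and the source may have more. Where it says the series, first, only, none or still open, it means among the compounds named here.

For the measured compounds named here, in a functional assay (Homo sapiens) for inhibition of Nucleic Acid, tested at 100 uM (a higher number here means more inhibition at the concentration tested (going by the name of the read-out), a lower number less inhibition), compound 1 `OCCNc1[nH]ccc2ncnc1-2` gives 3%, the lowest of the three numbers so far. Its nearest neighbour is compound 3 `[N-]=[N+]=Nc1nccc2c1ncn2C1O[C@H](CO)[C@@H](O)[C@H]1O`, which in this assay gives 4%, within the scatter of compound 1; the furthest is compound 2 `OC[C@H]1OC(n2cnc3c(Cl)nccc32)[C@H](O)[C@@H]1O`, which gives 76%, beyond the scatter of both. Going by the values given here, compounds 2 and 3 share a core that compound 1 does not, and the one step between measured compounds, a number 72 percentage points lower from compound 2 to compound 3 (beyond the scatter), concerns that pair alone.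

Compound 4 `CCNc1[nH]ccc2ncnc1-2` differs from compound 1 by hydrogen in place of hydroxy on a saturated chain carbon, two bonds along the chain from a nitrogen on an aromatic ring. Among the compounds with values here, no measured step touches this change: the step from compound 2 to compound 3 swaps one group on an aromatic carbon of a different core, while the change here sits on the saturated chain of compound 1 and removes a group rather than exchanging one. Within the data shown here, the only guide is the low starting point of compound 1 at 3%, and with compound 3 also low at 4%, nothing in the set points to a rise. The expected step is a number 1 percentage points higher from compound 1 to compound 4 (within the scatter), none beyond the scatter. Compound 4 is estimated at 4%, with a range of -8% to 16%.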

Compound 4, a percentage reported as inhibition, at one concentration (the size of the read-out at that concentration, not a potency): 3%
Compound 4: middle estimate off by 1 percentage points, on the high side; measured number inside the range.
By their numbers in this assay, from the lowest: compounds 1, 4 and 3 (each within the scatter of the next); then compound 2.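

In this assay, this first measured change on the saturated chain of the core of compound 1 gives no change at the digits printed from compound 1 to compound 4 (within the scatter) and places hydrogen and hydroxy on level terms at this carbon, two bonds along the chain from a nitrogen on an aromatic ring. With both compounds at the low end of the set, the pair shows that the hydroxy group supplies no inhibition on this core beyond what hydrogen supplies, though any contribution smaller than the usual scatter would stay unseen, and 2-hydroxyethyl and ethyl cannot be told apart here. No measurement at hand bears on why the two compounds read alike.

Going by these compounds, whether a different group on this chain, such as an amine, a carboxylic acid or a longer chain, would lift the number off this low level remains open. Also open, on these data alone, is whether chloro on an aromatic carbon of the core of compound 1 would bring it nearer to compound 2 at 76%, a question the present pair cannot address.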